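This account rests on a few compounds, and the source may have more. Where it says the series, first, only, none or still open, it means among the compounds named here.

In a functional assay on HL-60 cells (Homo sapiens) for antiproliferative activity, read by MTT assay, with a stated time of 72 h (a lower number here means a stronger inhibitor, a higher number a weaker inhibitor), compound 1 `NC1=NC2(CCOCC2)N(OCCCOc2cccc(Cl)c2Cl)C(N)=N1` gives 440 nM, compound 2 `NC1=NC2(CCOCC2)N(OCCCOc2ccccc2Cl)C(N)=N1` gives 660 nM, and compound 3 `CC(C)(C)c1ccc(OCCCON2C(N)=NC(N)=NC23CCOCC3)cc1` gives 870 nM. Compound 3 thus gives the highest of the three numbers, yet its gap to each of the others stays within the usual scatter, so none of the three can be ranked against the others. Compound 4 `NC1=NC2(CCOCC2)N(OCCCOc2ccccc2)C(N)=N1` differs from compound 3 by hydrogen in place of tert-butyl on an aromatic carbon. Among the compounds with values here, only one measured step removes a single group from the aromatic ring, and because a 1.5-fold higher number from compound 1 to compound 2 (0.18 log units; within the scatter) stayed within the scatter, the step from compound 3 to compound 4 in this assay is expected to be small as well, about a 1.3-fold higher number from compound 3 to compound 4 (0.10 log units; within the scatter). For compound 4 the estimate in this assay is therefore 1100 nM, with a range from 500 nM to 2500 nM.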

Compound 4, half-maximal inhibitory concentration: 2460 nM
Compound 4: the middle estimate sits 2.2-fold (0.35 log units) below what was measured; the measured number falls inside the stated range.
By their numbers in this assay, from the lowest: compounds 1, 2 and 3 (each within the scatter of the next); then compound 4.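

In this assay, within the data shown here, the bare phenyl ring of compound 4 separates clearly from the substituted rings: the loss of tert-butyl gives the first step beyond the scatter (a 2.8-fold higher number from compound 3 to compound 4 (0.45 log units; beyond the scatter)). The loss of the last chloro also goes beyond it (a 3.7-fold higher number from compound 2 to compound 4 (0.57 log units; beyond the scatter)), and the loss of both chloro groups goes further (a 5.6-fold higher number from compound 1 to compound 4 (0.75 log units; beyond the scatter)), whereas losing one chloro while another stays gave only a 1.5-fold higher number from compound 1 to compound 2 (0.18 log units; within the scatter). No available evidence explains these steps.

On these data alone, whether an amine or a carboxylic acid on this ring would match tert-butyl or chloro stays open. So does the effect of a longer chain linking this ring to the core.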